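The source may hold more compounds than are shown below. What is called first, only, known or untested is meant among the compounds shown, and "the series" means these compounds.

Measured compounds: compound 1 `COc1ccc(CNC(=O)CSc2nc3ccc(NC(=O)c4ccc(Cl)cc4)cc3s2)cc1` gives 7400 nM; compound 2 `O=C(CSc1nc2ccc(NC(=O)c3ccc(Cl)cc3)cc2s1)NCc1ccc(Cl)cc1` gives 17800 nM; compound 3 `COc1ccccc1C(=O)Nc1ccc2nc(SCC(=O)NCc3ccc(Cl)cc3)sc2c1` gives 600 nM.

In a functional assay on HepG2 cells (Homo sapiens) for cytotoxicity, read by MTT assay, with a stated time of 48 h (on this read-out lower numbers stand for stronger inhibition and higher numbers for weaker inhibition), compound 3 stands lowest of the three; the core of compound 3 differs from that of compound 2 by 2-methoxyphenyl in place of 4-chlorophenyl on a carbonyl carbon, a change that gave a 30-fold lower number from compound 2 to compound 3 (1.47 log units; beyond the scatter). Compound 4 `COc1ccc(CNC(=O)CSc2nc3ccc(NC(=O)c4ccccc4OC)cc3s2)cc1` is not yet measured. It differs from compound 3 by methoxy in place of chloro on an aromatic carbon. The same change, (methoxy in place of chloro on an aromatic carbon), has been made once before, from compound 2 to compound 1, where it gave a 2.4-fold lower number from compound 2 to compound 1 (0.38 log units; beyond the scatter). Both place lines read alike, so this is the same change on a different core. Within the data shown here, because compound 3 gives 600 nM and the earlier step was a 2.4-fold lower number from compound 2 to compound 1 (0.38 log units; beyond the scatter), compound 4 is expected to show a step of about a 1.7-fold lower number from compound 3 to compound 4 (0.23 log units; within the scatter) in this assay, somewhat tempered since only one prior step supports it. The estimate for compound 4 is 350 nM, expected between 120 nM and 1000 nM.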

Compound 4, half-maximal inhibitory concentration: 2100 nM
The estimate for compound 4 lay 6.0-fold (0.78 log units) below the measured number, outside the stated range (above it).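

In this assay, the change from 4-chlorobenzyl to 4-methoxybenzyl gave a 3.5-fold higher number from compound 3 to compound 4 (0.54 log units; beyond the scatter), so it did not carry over from the earlier core in direction or in size: the same change on two cores in this assay, a 2.4-fold lower number (0.38 log units; beyond the scatter) from compound 2 to compound 1 and a 3.5-fold higher number (0.54 log units; beyond the scatter) from compound 3 to compound 4, 8.4-fold (0.93 log units) apart, beyond the scatter of two such steps

The change from 4-chlorophenyl to 2-methoxyphenyl on the carbonyl carbon kept its direction, with a 3.5-fold lower number from compound 1 to compound 4 (0.55 log units; beyond the scatter), but not its size: the same change on two cores in this assay, a 30-fold lower number (1.47 log units; beyond the scatter) from compound 2 to compound 3 and a 3.5-fold lower number (0.55 log units; beyond the scatter) from compound 1 to compound 4, 8.4-fold (0.93 log units) apart, beyond the scatter of two such steps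

These four compounds show that neither step can be carried unchanged between these cores, but they do not show why, nor how either change would behave on a further core.

Going by these compounds, it remains open whether an amine or a carboxylic acid in place of the methoxy of the 4-methoxybenzyl group would follow either core. The same question stands for a longer chain in place of the benzyl.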